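A few compounds are considered here, and "the series" means these few. Any claim that something is new, unique, unknown or untested is made for them only; others in the source may bear on it.

Measured compounds, with their read-out in a functional assay on SR cells (Homo sapiens) for inhibition, read by sulforhodamine B assay, with a stated time of 48 h, tested at 1 uM; a higher number here means a weaker effect of the compound at the concentration tested, a lower number a stronger effect:

compound 1, `COc1cc(Cl)cc(-c2nn(-c3cccc(NC(=O)Nc4ccc(Cl)c(C(F)(F)F)c4)c3)cc2-c2ccncc2)c1`: 53%
compound 2, `COc1cc(Cl)cc(-c2nn(-c3cccc(NC(=O)Nc4cc(C(F)(F)F)cc(C(F)(F)F)c4)c3)cc2-c2ccncc2)c1`: 28%
compound 3, `COc1cc(Cl)cc(-c2nn(-c3cccc(NC(=O)Nc4ccc(Cl)c(Cl)c4)c3)cc2-c2ccncc2)c1`: 68%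

Compound 3 gives the highest number of the three, beyond the scatter from compound 1 and furthest from compound 2. Compound 4, `COc1cc(Cl)cc(-c2nn(-c3cccc(NC(=O)Nc4cccc(C(F)(F)F)c4)c3)cc2-c2ccncc2)c1`, is unmeasured; it differs from compound 3 by 3-(trifluoromethyl)phenyl in place of 3,4-dichlorophenyl on an amide-type nitrogen. Within the data shown here, one measured step bears on this: a number 15 percentage points higher from compound 1 to compound 3 (beyond the scatter). Compound 4 goes the opposite way, replacing chloro by trifluoromethyl, and in addition drops a second chloro, a change without a measured counterpart here. A step downward in this assay beyond the scatter is therefore expected, roughly a number 13 percentage points lower from compound 3 to compound 4 (beyond the scatter). The number for compound 4 is estimated at 55%, within 35% to 75%.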

Compound 4, a percentage reported as activity, at one concentration (the size of the read-out at that concentration, not a potency): 55%
Compound 4: middle estimate and measured number agree at the digits printed; measured number inside the range.
By their numbers in this assay, from the lowest: compound 2; then compounds 1 and 4 (each within the scatter of the next); then compound 3.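

In this assay, 3-(trifluoromethyl)phenyl in place of 3,4-dichlorophenyl on the amide-type nitrogen gives a number 13 percentage points lower from compound 3 to compound 4 (beyond the scatter) and so a stronger effect. The aromatic ring's substituents do not count equally: hydrogen in place of trifluoromethyl gives a number 27 percentage points higher from compound 2 to compound 4 (beyond the scatter) and a weaker effect, while hydrogen in place of chloro gives a number 2 percentage points higher from compound 1 to compound 4 (within the scatter) with no step beyond the scatter. No evidence at hand accounts for these steps.

Still open, on these data alone, is how a nitrile, a methoxy group or an amine would read on this ring. As far as these compounds go, whether the trifluoromethyl group alone is needed also stays open, with plain phenyl as the test.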